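This account rests on a few compounds, and the source may have more. Where it says the series, first, only, none or still open, it means among the compounds named here.

Compound 2 `CC(Sc1nc2c(cnn2C)c(=O)n1-c1ccccc1)c1cccc(F)c1` stands lowest of the two numbers in an assay on isolated protein for inhibition of aldehyde dehydrogenase 1A1 (Homo sapiens) (on this read-out lower numbers stand for stronger inhibition and higher numbers for weaker inhibition), at 151 nM; compound 1 `Cn1ncc2c(=O)n(-c3ccccc3)c(SC(C)(C)c3ccccc3)nc21` gives 1900 nM. Going by the values given here, the single step so far, a 13-fold lower number from compound 1 to compound 2 (1.10 log units; beyond the scatter), reworks the whole group on the sulfur and does not test a ring change alone. Compound 3 `CC(Sc1nc2c(cnn2C)c(=O)n1-c1ccccc1)c1ccncc1` differs from compound 2 by pyridin-4-yl in place of 3-fluorophenyl on a saturated chain carbon bound to a saturated chain carbon and a sulfur. Among the compounds with values here, no measured step bears on this change, so the direction is open, and only a moderate shift beyond the scatter, most likely towards a higher number, is expected. Compound 3 is expected at 400 nM, range 120 nM to 1300 nM, that is a 2.6-fold higher number from compound 2 to compound 3 (0.42 log units; beyond the scatter).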

Compound 3, half-maximal inhibitory concentration: 451 nM
Beside the measured number, compound 3's estimate is 1.1-fold (0.05 log units) below it; low and high end bracket the measured number.
By their numbers in this assay, from the lowest: compound 2; then compound 3; then compound 1.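

In this assay the ring on this saturated chain carbon matters by itself: pyridin-4-yl in place of 3-fluorophenyl gives a 3.0-fold higher number from compound 2 to compound 3 (0.48 log units; beyond the scatter) with the rest of the molecule unchanged. The exchange does not cancel what the 1-arylethyl type of group offers, since 1-(pyridin-4-yl)ethyl in place of 1-methyl-1-phenylethyl on a sulfur still gives a 4.2-fold lower number from compound 1 to compound 3 (0.62 log units; beyond the scatter) and stays beyond the scatter.

Loss of the fluorine and entry of the ring nitrogen remain unseparated, and plain phenyl or pyridin-3-yl on the same carbon would part them. Nothing available explains the size of this shift.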